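Methyl in place of hydrogen: expectation for compound 4

This account rests on a few compounds, and the source may have more. Where it says the series, first, only, none or still open, it means among the compounds named here.

Compound 1 `O=C(/C=C/c1ccc2c(c1)B(O)OC2)c1ccccc1` is the reference of the series. Among the compounds with values here, in a functional assay on HCT-116 cells (Homo sapiens) for cytotoxicity, read by MTT assay, with a stated time of 48 h (a lower number here means a stronger inhibitor, a higher number a weaker inhibitor), compound 1 gives 6100 nM, the lowest of the three numbers measured so far, although compound 3 sits within the scatter of it. Compound 2 `O=C(/C=C/c1ccc2c(c1)B(O)OC2)c1cccs1` carries thiophen-2-yl in place of phenyl on the carbonyl carbon and gives 14200 nM; the step of a 2.3-fold higher number from compound 1 to compound 2 (0.37 log units; beyond the scatter). Compound 3 `O=C(/C=C/c1ccc2c(c1)B(O)OC2)c1ccc(C(F)(F)F)cc1` carries trifluoromethyl in place of hydrogen on an aromatic carbon and gives 6300 nM; the step of a 1.0-fold higher number from compound 1 to compound 3 (0.01 log units; within the scatter).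

Compound 4 `Cc1cccc(C(=O)/C=C/c2ccc3c(c2)B(O)OC3)c1` differs from compound 1 as follows: methyl in place of hydrogen on an aromatic carbon. Within the data shown here, the step that bears on this is the one from compound 1 to compound 3, a substituent added to the same six-membered aromatic ring of carbon only, and it stayed within the scatter. Among the measured compounds shown here, the only step beyond the scatter, from compound 1 to compound 2, exchanges the ring itself and does not speak to a methyl group. For the measured compounds named here, no step in the data suggests that a small substituent on this ring moves the number.

Compound 4 is therefore expected to stay close to compound 1, with a step of a 1.1-fold higher number from compound 1 to compound 4 (0.03 log units; within the scatter) that is estimated to lie within the scatter. The estimate for compound 4 is 6500 nM, with a range from 3000 nM to 14000 nM.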

Compound 4, half-maximal inhibitory concentration: 6700 nM
Beside the measured number, compound 4's estimate is 1.0-fold (0.01 log units) below it; measured number inside the range.
By their numbers in this assay, from the lowest: compounds 1, 3 and 4 (each within the scatter of the next); then compound 2.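

In this assay, within the data shown here, the step of a 1.1-fold higher number from compound 1 to compound 4 (0.04 log units; within the scatter) gives the first reading for a substituent meta to a large group on the six-membered aromatic ring, and a single added carbon at this place leaves the number indistinguishable from that of the unsubstituted phenyl reference. The step of a 2.1-fold lower number from compound 2 to compound 4 (0.33 log units; beyond the scatter) lies beyond the scatter, as does a 2.3-fold higher number from compound 1 to compound 2 (0.37 log units; beyond the scatter), so the separation from the thiophen-2-yl member holds for the 3-methylphenyl group as it does for phenyl. Nothing available on these compounds explains either the flat methyl step or the gap to the thiophen-2-yl member.

The compounds shown leave open whether an amine or a carboxylic acid at this same place would shift the number beyond the scatter, as only methyl is shown there. Also open, as far as these compounds go, is whether a longer chain, such as a butyl group, would stay as flat as methyl, and so whether any substituent on this ring can lower the number relative to compound 1.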